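The source may report more compounds than this note shows. Statements on the series, on what has been measured and on what is new or still open speak of the compounds shown alone.

Compound 1 `CCN1CCN(c2ccc(S(=O)(=O)Oc3ccccc3OC)cc2)C1=O` carries a 2-methoxyphenyl group on an oxygen of the shared core. In a functional assay on MCF7 cells (Homo sapiens) for antiproliferative activity, read by sulforhodamine B assay, with a stated time of 48 h (a lower number here means a stronger inhibitor, a higher number a weaker inhibitor), compound 1 reads > 100000 nM, which is a limit and not a number. Compound 3 `CCN1CCN(c2ccc(S(=O)(=O)Oc3ccc(OC)cc3)cc2)C1=O`, with 4-methoxyphenyl on that oxygen, reads > 100000 nM, also a limit. Compound 2 `CCN1CCN(c2ccc(S(=O)(=O)Oc3cccc(I)c3)cc2)C1=O`, with 3-iodophenyl there, gives a true number, 1900 nM. Changing that group produced large steps: an at least 52-fold lower number from compound 1 to compound 2 (1.72 log units; beyond the scatter), then an at least 52-fold higher number from compound 2 to compound 3 (1.72 log units; beyond the scatter). Compound 1 thus stands at the limit of > 100000 nM in this assay, at which 2 of the 3 values shown sit.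

Compound 4 `CCCCN1CCN(c2ccc(S(=O)(=O)Oc3ccccc3OC)cc2)C1=O` keeps the 2-methoxyphenyl group and differs elsewhere: ethyl in place of hydrogen on a saturated chain carbon, two bonds along the chain from an amide-type nitrogen in a ring. The same difference reads ethyl to butyl. Going by the values given here, no measured step touches this chain, and the large steps above were all made on the oxygen, so they give no direct size for this change. Compound 4 keeps the group that left compound 1 at > 100000 nM, so no large step is expected in this assay, and any readable change would be toward a lower number. The estimated outcome is an at least 1.2-fold lower number from compound 1 to compound 4 (0.09 log units; that floor lies within the scatter). For compound 4 the expected value is 80000 nM, with an estimated range of 20000 nM to 200000 nM.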

Compound 4, half-maximal inhibitory concentration: 3800 nM
Compound 4: middle estimate off by 21-fold (1.32 log units), on the high side, outside the stated range (below it).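

Among the earlier compounds, only the group on the oxygen had moved the read-out in this assay; this result shows that the chain on the other side of the shared core can move it too, with an at least 26-fold lower number from compound 1 to compound 4 (1.42 log units; beyond the scatter). The 2-methoxyphenyl group is the same in both compounds of this step, so that group alone does not hold a compound at the limit. The step gives a floor and not an exact size, because compound 1 carries a limit and not a number: the limit of > 100000 nM in this assay, at which 2 of the 4 values shown sit.

The compounds shown leave open whether a propyl chain, a hexyl chain or a chain ending in an amine would give a lower or a higher number in this assay. They also leave open whether butyl in place of ethyl gives a similar step when 3-iodophenyl or 4-methoxyphenyl sits on the oxygen.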